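This account rests on a few compounds, and the source may have more. Where it says the series, first, only, none or still open, it means among the compounds named here.

Of the compounds shown here, three built on a shared core have been measured so far in a functional assay on BCG823 cells (Homo sapiens) for antiproliferative activity, read by MTT assay, with a stated time of 48 h (on this read-out higher numbers stand for weaker inhibition and lower numbers for stronger inhibition), and they fall into two levels. Compound 1 `O=c1cc(-c2ccccc2)oc2cc(O)c(OCCCN3CCCCC3)c(O)c12` gives 60900 nM and compound 2 `COc1cc2oc(-c3ccccc3)cc(=O)c2c(O)c1OCCCCN1CCN(C)CC1` gives 53500 nM in this assay and these two numbers lie within the usual scatter of each other. Compound 3 `CN1CCN(CCCOc2c(OCc3ccccc3)cc3oc(-c4ccccc4)cc(=O)c3c2O)CC1` gives 4100 nM and stands clearly lower than both, beyond the scatter. It differs from compound 2 in more than one place, however, so its number cannot be tied to any single change. Compound 2 therefore stands with compound 1 at the weaker level of the three.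

The next compound is compound 4 `CCN(CC)CCCOc1c(OC)cc2oc(-c3ccccc3)cc(=O)c2c1O` and it departs from compound 2 at one place only. The change reads diethylamino in place of (4-methylpiperazin-1-yl)methyl on a saturated chain carbon, three bonds along the chain from an oxygen on an aromatic ring and the rest of the structure stays the same. Among the compounds with values here, no measured pair isolates this change. The expectation rests on compound 1 at 60900 nM and compound 2 at 53500 nM which carry different amine side chains yet show no gap beyond the scatter. The estimated change is a 1.3-fold lower number from compound 2 to compound 4 (0.13 log units; within the scatter) and so no step beyond the scatter is expected in this assay for this swap. For compound 4 the estimated value is 40000 nM with an expected range of 12000 nM to 90000 nM in this assay once it is measured.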

Compound 4, half-maximal inhibitory concentration: 5700 nM
The estimate for compound 4 lay 7.0-fold (0.85 log units) above the measured number; measured number outside the range, below it.
By their numbers in this assay, from the lowest: compounds 3 and 4 (each within the scatter of the next); then compounds 2 and 1 (each within the scatter of the next).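

In this assay, this position on the side chain proves sensitive to a single change: diethylamino in place of (4-methylpiperazin-1-yl)methyl, on a saturated chain carbon three bonds along the chain from an oxygen on an aromatic ring, gives a 9.4-fold lower number from compound 2 to compound 4 (0.97 log units; beyond the scatter). The earlier compounds shown here could not show this, as compound 1 and compound 2 differ in more than one place, so their closeness said nothing about any one amine, whereas this step ties a gap beyond the scatter to one change on an otherwise unchanged structure. Nothing available here accounts for the size of the step.

The same difference also reads 3-(4-methylpiperazin-1-yl)propyl to 2-(diethylamino)ethyl, so the amine and the length of the chain that carries it change together, and the step alone cannot separate the two. From the compounds shown here alone, it remains open how a 4-methylpiperazine on a shorter chain or a diethylamino on a longer chain would compare, and whether other amines at the chain end, such as dimethylamino, pyrrolidine or morpholine, would stand with compound 4 or with compound 2.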